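Methoxy in place of methyl on the aromatic carbon

This account rests on a few compounds, and the source may have more. Where it says the series, first, only, none or still open, it means among the compounds named here.

Going by the values given here, compound 2 `COP(=O)(OC)[Se]c1ccc(C)cc1` gives 11.5% in a functional assay, tested at 10 uM (on this read-out lower numbers stand for a weaker effect and higher numbers for a stronger effect at the one concentration tested), and stands at the top of the two numbers so far, though that is a difference within the scatter: compound 1 `COP(=O)(OC)[Se]c1ccccc1` gives 5.02%, and the step of a number 6.5 percentage points higher from compound 1 to compound 2 (within the scatter) is within the scatter. Compound 3 `COc1ccc([Se]P(=O)(OC)OC)cc1` differs from compound 2 by methoxy in place of methyl on an aromatic carbon. Among the compounds with values here, no measured step exchanges methoxy for methyl; the only step at this place, a number 6.5 percentage points higher from compound 1 to compound 2 (within the scatter), was within the scatter, so no step beyond the scatter is expected in this assay. Compound 3 is expected to give 12%, within 4% to 22%. The expected step is a number 0.5 percentage points higher from compound 2 to compound 3 (within the scatter).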

Compound 3, a percentage reported as activity, at one concentration (the size of the read-out at that concentration, not a potency): 6.76%
Compound 3: middle estimate off by 5.2 percentage points, on the high side; the measured number falls inside the stated range.
By their numbers in this assay, from the lowest: compounds 1, 3 and 2 (each within the scatter of the next).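

In this assay, methoxy in place of methyl gives a number 4.7 percentage points lower from compound 2 to compound 3 (within the scatter) and methoxy in place of hydrogen gives a number 1.7 percentage points higher from compound 1 to compound 3 (within the scatter) on the same aromatic carbon, so methoxy is set apart from neither group at this place. Hydrogen, methyl and methoxy on this aromatic carbon now all lie within the scatter of one another, and the hydrogen-bond acceptor that enters with methoxy brings no step beyond it. No measured evidence bears on this result.
As far as these compounds go, whether any group at this place can move the read-out beyond the scatter stays open. An amine, a carboxylic acid or a longer chain here would test that.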